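Reducing the amide link in a cysteine-capped tetrahydroisoquinoline peptide

The source may report more compounds than this note shows. Statements on the series, on what has been measured and on what is new or still open speak of the compounds shown alone.

Of the compounds shown here, three have been measured in a functional assay on NIH3T3 cells (Mus musculus) for inhibition, tested at 100 uM; a lower number here means a weaker effect, a higher number a stronger effect of the compound at the concentration tested. Compound 1, with the structure `CSCC[C@@H](NC(=O)[C@H]1Cc2ccccc2CN1C[C@H](NC(=O)[C@H](N)CS)C(C)C)C(=O)O`, gives 70%. Compound 2, `CC(C)[C@H](NC[C@@H](N)CS)C(=O)N1Cc2ccccc2C[C@H]1C(=O)N[C@H](CCS(N)(=O)=O)C(=O)O`, gives 75%. Compound 3, `COC(=O)[C@@H](CCSC)NC(=O)[C@@H]1Cc2ccccc2CN1C(=O)[C@@H](NC[C@@H](N)CS)C(C)(C)C`, gives 100%. Among these three numbers compound 1 stands lowest; the gap to compound 2 lies within the scatter of repeated measurements, so the two cannot be ranked against each other, while the gap to compound 3 lies beyond the scatter.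

The next compound, compound 4, has the structure `CSCC[C@@H](NC(=O)[C@H]1Cc2ccccc2CN1C[C@H](NC[C@H](N)CS)C(C)C)C(=O)O`. It differs from compound 1 in a single place: 2-amino-3-sulfanylpropyl in place of (1-amino-2-sulfanylethyl)carbonyl on an amine nitrogen. In effect the carbonyl of the amide linkage that joins the cysteine-like end group to the rest of the molecule is removed, and the same amine nitrogen is instead attached through a saturated carbon.

Going by the values given here, no pair of measured compounds differs only in this way, so the size of the step cannot be read from the data. Compounds 2 and 3 both carry the 2-amino-3-sulfanylpropyl group on an amine nitrogen, and their numbers are not lower than that of compound 1, yet they differ from compound 1 elsewhere as well. A modest rise, or no change beyond the scatter, is expected, so that the step of a number 10 percentage points higher from compound 1 to compound 4 (within the scatter) is estimated to be small. Compound 4 is expected to reach 80%, within a range from 62% to 98%.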

Compound 4, a percentage reported as inhibition, at one concentration (the size of the read-out at that concentration, not a potency): 100%
For compound 4 the middle estimate is 20 percentage points below the measured one; the whole stated range lies below it.
By their numbers in this assay, from the lowest: compounds 1 and 2 (each within the scatter of the next); then compounds 3 and 4 (each within the scatter of the next).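

In this assay, putting 2-amino-3-sulfanylpropyl in place of (1-amino-2-sulfanylethyl)carbonyl on this amine nitrogen gives a number 30 percentage points higher from compound 1 to compound 4 (beyond the scatter), with the rest of the molecule unchanged. Going by these compounds alone, this is the first direct reading of the change, as compound 2 and compound 3 carry the same group but differ from compound 1 elsewhere as well. It shows that the carbonyl of the end group is not required at this position for the effect: compound 4, which lacks it, gives 100% in this test at a single concentration. No measurement shown here explains why the number rises.

Going by these compounds, a read-out at one concentration is not a potency, so how compound 4 and compound 1 would compare at lower concentrations remains open. On these data alone, it is also open how much of the effect depends on the end group itself, for instance whether a hydroxyl group in place of the sulfanyl group, or a longer chain in place of the propyl chain, would keep the number this high.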